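The compounds below may be only part of what the source reports. "The series", "measured", "known", "first", "only" and "open" are said of these compounds alone.

Compound 3 `Cc1nsc2c1ncn2[C@@H]1O[C@H](CO)[C@@H](O)[C@@H]1O` is one of three measured members of this series, alongside compound 1 `Cc1nsc2c1ncn2[C@H]1C[C@H](O)[C@@H](CO)O1` and compound 2 `CSc1nc2c(C)nsc2n1[C@H]1C[C@H](O)[C@@H](CO)O1`. In a functional assay on KB cells (Homo sapiens) for antiproliferative activity (on this read-out higher numbers stand for weaker inhibition and lower numbers for stronger inhibition), compound 3 gives only the assay limit, > 100000 nM. Compound 1 likewise returns only the limit > 100000 nM. Compound 2 too returns only the limit > 100000 nM. All three sit at the limit of > 100000 nM in this assay, at which 3 of the 3 values shown sit, so the step that the two limits leave unreadable from compound 1 to compound 2 and the step that the two limits leave unreadable from compound 1 to compound 3 cannot be read in size. Compound 4 `Cc1nsc2c1nc(SCc1ccccc1)n2[C@@H]1O[C@H](CO)[C@@H](O)[C@@H]1O` differs from compound 3 by benzylsulfanyl in place of hydrogen on an aromatic carbon. Among the compounds with values here, no measured step bears readably on this change, and none of the three compounds shows measurable inhibition. Compound 4 is therefore expected to remain near the limit, with an estimated step of a number no higher from compound 3 to compound 4 (the limit leaves the size open) of no readable direction. For compound 4 the estimate is 100000 nM, ranging from 30000 nM to 300000 nM.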

Compound 4, half-maximal inhibitory concentration: > 100000 nM
Compound 4 gave a limit, no number (the forecaster's own chance of this, stated with the estimate: 80%); the middle value lies on the limit itself.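

In this assay no step can be read between compound 3 and compound 4, because both give only a limit and no number: the limit of > 100000 nM in this assay, at which 4 of the 4 values shown sit. The compounds shown leave open how strongly, if at all, any of them inhibits in this assay, and so what benzylsulfanyl in place of hydrogen changes.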